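The source may hold more compounds than are shown below. What is called first, only, known or untested is meant among the compounds shown, and "the series" means these compounds.

The measured compounds:
compound 1, `CCc1cn([C@H]2C[C@@H]3OP(=O)(O)OC[C@H]3O2)c(=O)[nH]c1=O`; in a functional assay on Raji cells (Homo sapiens) (a higher number here means a weaker inhibitor, a lower number a stronger inhibitor), compound 1 gives > 500 ug/mL, a limit of the assay rather than a number.
compound 2, `CCCCCc1cn([C@H]2C[C@H](O)[C@@H](CO)O2)c(=O)[nH]c1=O`; in this assay compound 2 gives 328 ug/mL.
compound 3, `CCCc1cn([C@H]2C[C@H](O)[C@@H](CO)O2)c(=O)[nH]c1=O`; in this assay compound 3 gives > 500 ug/mL, again a limit of the assay.

Compound 1 therefore stands at the limit of > 500 ug/mL in this assay, at which 2 of the 3 values shown sit, and its place among the three cannot be fixed more closely than that. The unmeasured compound 4, `CCCCCc1cn([C@H]2C[C@@H]3OP(=O)(O)OC[C@H]3O2)c(=O)[nH]c1=O`, differs from compound 1 by propyl in place of hydrogen on a saturated chain carbon, two bonds along the chain from an aromatic carbon. One measured step speaks to this change, running the opposite way on the shared core without the cyclic phosphate: an at least 1.5-fold higher number from compound 2 to compound 3 (0.18 log units; that floor lies within the scatter), a shortening of the chain that did not lower the number. Turning that step around, a lengthening of the chain on compound 1 is expected to give, in this assay, a lower number, though only by a small margin, and since compound 1 sits at a limit the assay may well report only a limit again. For compound 4 the expected value is 400 ug/mL, between 200 ug/mL and 800 ug/mL, which means a step of an at least 1.2-fold lower number from compound 1 to compound 4 (0.09 log units; that floor lies within the scatter).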

Compound 4, concentration for 50% inhibition: > 500 ug/mL
Compound 4 was reported as a limit (the forecaster's own chance of this, stated with the estimate: 50%); middle value at least 1.2-fold (0.09 log units) from the limit.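

Compound 1 and compound 4 both sit at a limit of this assay, and no step between them can be read: the limit of > 500 ug/mL in this assay, at which 3 of the 4 values shown sit.

The compounds shown leave open whether propyl in place of hydrogen at this place changes the number at all on the core of compound 1.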